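The compounds below may be only part of what the source reports. "The series", "measured", "known", "first", "only" and "open" are said of these compounds alone.

Within the data shown here, in a functional assay on MCF7 cells (Homo sapiens) for inhibition, read by sulforhodamine B assay (on this read-out higher numbers stand for weaker inhibition and lower numbers for stronger inhibition), compound 1 `Cc1ccc(NC2=CC(=O)c3nc4n(c3C2=O)[C@H]2OC[C@@H](O)[C@H]2OC4)cc1` gives 1660 nM, the lowest of the two numbers measured so far. Compound 2 `COc1ccccc1NC1=CC(=O)c2c(nc3n2[C@H]2OC[C@@H](O)[C@H]2OC3)C1=O` gives 6580 nM in this assay, a gap beyond the scatter. For compound 3 `O=C1C(N2CCCC2)=CC(=O)c2c1nc1n2[C@H]2OC[C@@H](O)[C@H]2OC1` the this assay reports only a limit, > 16000 nM, and not a number. Among the measured compounds shown here, the one measured step that bears on the change under study is the exchange of an arylamino group for a cyclic amine: an at least 2.4-fold higher number from compound 2 to compound 3 (0.38 log units; beyond the scatter). Compound 4 `O=C1C=C(N2CCCCC2)C(=O)c2c1nc1n2[C@H]2OC[C@@H](O)[C@H]2OC1` differs from compound 1 in the same kind of way: piperidin-1-yl in place of (4-methylphenyl)amino on a double-bonded ring carbon. Given the at least modest weakening seen in an at least 2.4-fold higher number from compound 2 to compound 3 (0.38 log units; beyond the scatter), the writer expects the number for compound 4 to rise beyond the scatter as well, by roughly a 5.4-fold higher number from compound 1 to compound 4 (0.73 log units; beyond the scatter). The reading may also come out as the limit of > 16000 nM in this assay, at which 1 of the 3 values shown sits. The estimate for compound 4 in this assay is therefore 9000 nM, with a range from 3500 nM to 20000 nM.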

Compound 4, half-maximal inhibitory concentration: > 8000 nM
Compound 4 ended at the assay's limit (the forecaster's own chance of this, stated with the estimate: 35%); the middle value does not contradict the limit.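

Putting piperidin-1-yl in place of (4-methylphenyl)amino on a double-bonded ring carbon gives an at least 4.8-fold higher number from compound 1 to compound 4 (0.68 log units; beyond the scatter) in this assay. The weakening seen earlier with pyrrolidin-1-yl therefore recurs in a second pair, with a different arylamino group leaving and a different cyclic amine entering, and neither pair goes against it. Compound 4 is reported only as a limit, so the full size of this step stays unknown: the limit of > 8000 nM in this assay, at which 1 of the 4 values shown sits.

The exchange removes the six-membered aromatic ring and the hydrogen-bond donor together, so these compounds cannot show which of the two changes matters. A cyclohexylamino group, which keeps the amine hydrogen without the aromatic ring, or an N-methyl-N-(4-methylphenyl)amino group, which keeps the aromatic ring without that hydrogen, would separate them.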